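Swapping a Sulfonyl for Propargyl on the Ring Nitrogen

The compounds below may be only part of what the source reports. "The series", "measured", "known", "first", "only" and "open" are said of these compounds alone.

Compound 1 `CCN(CC)c1ccc2cc(C(=O)c3ccc(N4CCN(C(=O)CN5CCN(C(=O)/C=C/c6ccccc6)CC5)CC4)cc3)oc2c1` is measured in a functional assay on SGC-7901 cells (Homo sapiens) for cytotoxicity, read by MTT assay, with a stated time of 48 h (on this read-out lower numbers stand for stronger inhibition and higher numbers for weaker inhibition), at 1140 nM. Compound 2 `CCN(CC)c1ccc2cc(C(=O)c3ccc(N4CCN(C(=O)CN5CCN(S(=O)(=O)c6ccc(C#N)cc6)CC5)CC4)cc3)oc2c1` returns only a limit in this assay, namely > 40000 nM. That value is the limit of > 40000 nM in this assay, at which 1 of the 2 values shown sits, so compound 2 stands beyond the range the test reports and no number is known for it. The step of an at least 35-fold higher number from compound 1 to compound 2 (1.54 log units; beyond the scatter) shows that the group carried on this ring nitrogen weighs heavily on the read-out. Compound 3 `C#CCN1CCN(CC(=O)N2CCN(c3ccc(C(=O)c4cc5ccc(N(CC)CC)cc5o4)cc3)CC2)CC1` is not yet measured; it differs from compound 2 by propargyl in place of (4-cyanophenyl)sulfonyl on an amine nitrogen in a ring. Among the compounds with values here, no measured step pairs a propargyl group with either earlier group on that nitrogen, so the expectation rests only on compound 1 and compound 2: the small alkyl group is unlike the sulfonyl that accompanied the loss and unlike the acyl of compound 1. Compound 3 is therefore expected to move by an at least 8.0-fold lower number from compound 2 to compound 3 (0.90 log units; beyond the scatter) toward stronger inhibition. The estimated value for compound 3 in this assay is 5000 nM, with a range from 800 nM to 40000 nM.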

Compound 3, half-maximal inhibitory concentration: 20100 nM
For compound 3 the middle estimate is 4.0-fold (0.60 log units) below the measured one; measured number inside the range.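

Propargyl in place of (2-phenylethenyl)carbonyl on this ring nitrogen gives an 18-fold higher number from compound 1 to compound 3 (1.25 log units; beyond the scatter), so the (4-cyanophenyl)sulfonyl group is not the only replacement that goes with a large rise in the number. Against that sulfonyl group the change reads an at least 1.9-fold lower number from compound 2 to compound 3 (0.29 log units; that floor lies within the scatter), which is only a floor and leaves the order of the two replacements unsettled. Compound 2 gives only a limit in this assay: the limit of > 40000 nM in this assay, at which 1 of the 3 values shown sits.

The compounds shown leave open which part of the (2-phenylethenyl)carbonyl group goes with the lower number of compound 1, the carbonyl or the phenyl ring with its double bond. An acetyl group and a benzyl group on this ring nitrogen would separate those two parts, and neither is among the compounds shown.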